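Homologating the acid chain on compound 2

The source may hold more compounds than are shown below. What is called first, only, known or untested is meant among the compounds shown, and "the series" means these compounds.

Compound 2, `CCn1cc(C(CC)(CC)c2ccc(C#CC(O)(CC)CC)c(C)c2)cc1C(=O)NCC(=O)O`, gives the higher of the two numbers measured in an assay on cells for agonist activity at vitamin D3 receptor (Homo sapiens), read by microscopy; on this read-out lower numbers stand for an effect already at smaller amounts and higher numbers for an effect only at larger amounts of compound: compound 2 gives 54.3 nM. For the measured compounds named here, its closest measured relative is compound 1, `CCn1cc(C(CC)(CC)c2ccc(C#CC(O)(CC)CC)c(C)c2)cc1C(=O)NCCN(C)C`, in which compound 1 gives 19.3 nM; the one change between them, a 2.8-fold higher number from compound 1 to compound 2 (0.45 log units; beyond the scatter), is the only measured step in this set. The next compound, compound 3, `CCn1cc(C(CC)(CC)c2ccc(C#CC(O)(CC)CC)c(C)c2)cc1C(=O)NCCC(=O)O`, keeps the acid but moves it out by one carbon: carboxymethyl in place of carboxy on a saturated chain carbon bound to an amide-type nitrogen. Going by the values given here, no measured step in this set changes the length of the chain that carries the acid, so the single step from compound 1 to compound 2 bears on the new change only loosely, by showing that the group on the amide-type nitrogen can shift this assay modestly. With that in mind, compound 3 is expected to stay near compound 2, with a step of a 1.1-fold higher number from compound 2 to compound 3 (0.04 log units; within the scatter) in this assay, not clearly beyond the scatter in either direction. Compound 3 is therefore estimated at 60 nM, with a range from 25 nM to 150 nM.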

Compound 3, half-maximal effective concentration: > 50 nM
Compound 3 gave a limit, no number (the forecaster's own chance of this, stated with the estimate: 5%); the middle value does not contradict the limit.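

In this assay compound 3 carries only a limit, > 50 nM, and not a number. Even so, the limit gives this position a second acid to set against the dimethylamino compound, an at least 2.5-fold higher number from compound 1 to compound 3 (0.41 log units; beyond the scatter), and this lies in the same direction as a 2.8-fold higher number from compound 1 to compound 2 (0.45 log units; beyond the scatter), so both acid chains shown give higher numbers than compound 1, with no compound shown going against this. The step between the two acids cannot be read, so the longer chain adds no measured information on how the length of the acid chain matters, and the whole comparison rests on a single censored entry: the limit of > 50 nM in this assay, at which 1 of the 3 values shown sits.

The compounds shown leave open where compound 3 truly lies relative to compound 2, and so whether the move from carboxymethyl to 2-carboxyethyl changes anything in this read-out. They also leave open how a still longer chain ending in a carboxylic acid would behave, and whether an ester, a primary amide or a dimethylamino group on the longer chain would give a number closer to that of compound 1.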